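The source may hold more compounds than are shown below. What is called first, only, known or untested is meant among the compounds shown, and "the series" means these compounds.

Working notes on the series.

Three compounds carry the shared core, compound 1 `COCC#Cc1cc(C(O)(C(F)(F)F)C(F)(F)F)cnc1N1CCN(S(=O)(=O)c2ccc(N)nc2)CC1`, compound 2 `Nc1ccc(S(=O)(=O)N2CCN(c3ncc(C(O)(C(F)(F)F)C(F)(F)F)cc3C#CCCO)CC2)cn1` and compound 3 `Nc1ccc(S(=O)(=O)N2CCN(c3ncc(C(O)(C(F)(F)F)C(F)(F)F)cc3-c3cccc(F)c3)CC2)cn1`. In an ADME assay (liver) for metabolic stability, with Liver microsome (Homo sapiens) as the target, using microsomes and NADPH, with a stated time of 30 min, tested at 1 uM (on this read-out lower numbers stand for slow clearance and higher numbers for fast clearance), compound 1 gives 15 mL.min-1.g-1. In this assay compound 3 gives 25 mL.min-1.g-1, the highest of the two numbers shown. For compound 2 the read-out in this assay is a limit of the assay, < 14 mL.min-1.g-1, the same floor as the limit of < 14 mL.min-1.g-1 in this assay, at which 1 of the 3 values shown sits. The two steps into compound 3 are a 1.7-fold higher number from compound 1 to compound 3 (0.22 log units; within the scatter) and an at least 1.7-fold higher number from compound 2 to compound 3 (0.25 log units; that floor lies within the scatter).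

Compound 4 `Cc1ccc(-c2cc(C(O)(C(F)(F)F)C(F)(F)F)cnc2N2CCN(S(=O)(=O)c3ccc(N)nc3)CC2)cn1` is not yet measured. It differs from compound 3 in one place: 6-methylpyridin-3-yl in place of 3-fluorophenyl on an aromatic carbon.

Among the measured compounds shown here, none of the measured steps swaps one aromatic ring for another; the steps into compound 3 exchange a chain bearing a triple bond for 3-fluorophenyl, and both stay within the scatter. For the measured compounds named here, no step therefore bears directly on a 6-methylpyridin-3-yl in place of 3-fluorophenyl, and no basis exists for expecting a move beyond the scatter in this assay in either direction. Compound 4 is expected to give about 20 mL.min-1.g-1 in this assay, with a range of 10 mL.min-1.g-1 to 40 mL.min-1.g-1, which corresponds to an estimated step of a 1.3-fold lower number from compound 3 to compound 4 (0.10 log units; within the scatter).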

Compound 4, intrinsic clearance in microsomes: 43 mL.min-1.g-1
Estimate against measurement, compound 4: 2.2-fold (0.33 log units) below, and the stated range ends below it.
By their numbers in this assay, from the lowest: compounds 1, 3 and 4 (each within the scatter of the next, the first and the last beyond it). At a limit, below all of these: compound 2.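

Among the compounds shown here, at this position, on an aromatic carbon ortho to a large group, one aromatic ring is now exchanged for another, and (a 1.7-fold higher number from compound 3 to compound 4 (0.24 log units; within the scatter)) this exchange stays within the scatter in this assay as the earlier steps into compound 3 did. What is new is a separation beyond the scatter at this position: replacing a chain bearing a triple bond with 6-methylpyridin-3-yl gives (a 2.9-fold higher number from compound 1 to compound 4 (0.46 log units; beyond the scatter)) and (an at least 3.0-fold higher number from compound 2 to compound 4 (0.48 log units; beyond the scatter)), whereas the same kind of exchange for 3-fluorophenyl stayed within the scatter. The second of these steps rests on compound 2, whose read-out is a limit of the assay and not a number: the limit of < 14 mL.min-1.g-1 in this assay, at which 1 of the 4 values shown sits.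

The compounds shown do not separate the ring nitrogen from the methyl group of 6-methylpyridin-3-yl, which a pyridin-3-yl without the methyl or a 4-methylphenyl would do. Also open, on these data alone, is how an amine or a carboxylic acid on the entering aromatic ring, or a longer chain bearing a triple bond, would read in this assay.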